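The source may report more compounds than this note shows. Statements on the series, on what has been measured and on what is new or still open speak of the compounds shown alone.

Measured so far in an in vitro assay on Sf9 cells for inhibition of Rho-associated protein kinase 2 (Homo sapiens), read by TR-FRET, with a stated time of 25 min; on this read-out higher numbers stand for weaker inhibition and lower numbers for stronger inhibition: compound 1 `O=c1[nH]c([C@@H]2CN(Cc3ccccc3)C[C@H]2c2ccccc2F)nc2ccc(-c3cn[nH]c3)cc12` gives 49 nM; compound 2 `COc1ccc([C@@H]2CN(Cc3ccccc3)C[C@H]2c2nc3ccc(-c4cn[nH]c4)cc3c(=O)[nH]2)cc1` gives 88 nM; compound 3 `NCCC(=O)NC(c1ccc(Cl)cc1)c1nc2ccc(-c3cn[nH]c3)cc2c(=O)[nH]1` gives 6 nM.

Compound 2 carries the highest of the three numbers. Its nearest neighbour is compound 1, whose value lies within the scatter of it, while compound 3 sits furthest away, beyond the scatter. Compound 4 `O=c1[nH]c([C@@H]2CN(Cc3ccccc3)C[C@H]2c2cccc(F)c2)nc2ccc(-c3cn[nH]c3)cc12` differs from compound 2 by 3-fluorophenyl in place of 4-methoxyphenyl on a saturated ring carbon. Within the data shown here, the only measured step of the same kind, a 1.8-fold higher number from compound 1 to compound 2 (0.25 log units; within the scatter), exchanged one substituted phenyl ring for another on this saturated ring carbon and stayed within the scatter. Compound 3 differs in several places at once, so it says nothing about this single change. No movement beyond the scatter is therefore expected. Compound 4 is estimated at 60 nM, with a range from 25 nM to 150 nM. The expected step is a 1.5-fold lower number from compound 2 to compound 4 (0.17 log units; within the scatter).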

Compound 4, half-maximal inhibitory concentration: 225 nM
For compound 4 the middle estimate is 3.8-fold (0.57 log units) below the measured one; the measured number lies above the stated range.
By their numbers in this assay, from the lowest: compound 3; then compounds 1 and 2 (each within the scatter of the next); then compound 4.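

This position is less forgiving than the earlier pair suggested: 3-fluorophenyl in place of 4-methoxyphenyl gives a 2.6-fold higher number from compound 2 to compound 4 (0.41 log units; beyond the scatter) and so moves beyond the scatter. With fluorine present in both rings, 3-fluorophenyl in place of 2-fluorophenyl gives a 4.6-fold higher number from compound 1 to compound 4 (0.66 log units; beyond the scatter) and shows that the two fluorophenyl groups are not interchangeable here. Nothing measured here explains these shifts. Still open, on these data alone, is how an amine or a carboxylic acid on this phenyl ring would behave. Also open, as far as these compounds go, is whether a longer chain in place of the benzyl group would change the picture.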